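This account rests on a few compounds, and the source may have more. Where it says the series, first, only, none or still open, it means among the compounds named here.

Working notes on the chalcone series built on the shared core of compound 1 `COc1cc(C(=O)/C=C/c2cn(-c3ccccc3)nc2-c2ccsc2)cc(OC)c1OC`, in which the aryl ring on the five-membered aromatic ring with 2 nitrogen is varied. In a functional assay on HCT-116 cells (Homo sapiens) for inhibition, read by sulforhodamine B assay, with a stated time of 72 h (a higher number here means a weaker inhibitor, a lower number a stronger inhibitor), compound 1 gives 3200 nM. For the measured compounds named here, compound 2 `COc1cc(C(=O)/C=C/c2cn(-c3ccccc3)nc2-c2cccnc2)cc(OC)c1OC` carries pyridin-3-yl at that position and gives 8600 nM in this assay, the highest of the three numbers so far; the step of a 2.7-fold higher number from compound 1 to compound 2 (0.43 log units; beyond the scatter) is beyond the scatter, while the gap to compound 3 is not. Compound 3 `COc1ccc(C(=O)/C=C/c2cn(-c3ccccc3)nc2-c2cccnc2)cc1OC` drops one methoxy from the trimethoxyphenyl part and gives 4300 nM, so the step of a 2.0-fold lower number from compound 2 to compound 3 (0.30 log units; within the scatter) shows no real change.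

Compound 4 `COc1cc(C(=O)/C=C/c2cn(-c3ccccc3)nc2-c2ccncc2)cc(OC)c1OC` differs from compound 2 by pyridin-4-yl in place of pyridin-3-yl on an aromatic carbon. Going by the values given here, no measured pair moves a nitrogen within the same ring; the nearest comparison is the swap of thiophen-3-yl for pyridin-3-yl, which gave a modest shift, and the methoxy change, which stayed inside the scatter. The step of a 1.1-fold lower number from compound 2 to compound 4 (0.03 log units; within the scatter) is therefore expected to be small, without a clear direction, and most likely within the scatter of this assay. Compound 4 is estimated at 8000 nM in this assay, with a range of 3000 nM to 22000 nM.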

Compound 4, half-maximal inhibitory concentration: 300 nM
Estimate against measurement, compound 4: 27-fold (1.43 log units) above, outside the stated range (below it).
By their numbers in this assay, from the lowest: compound 4; then compounds 1, 3 and 2 (each within the scatter of the next, the first and the last beyond it).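

Moving the ring nitrogen alone, with the same atoms and the same counts for the entering and leaving groups, gives a 29-fold lower number from compound 2 to compound 4 (1.46 log units; beyond the scatter) in this assay, so at this position the result depends on how the pyridine ring is attached and not only on its being a pyridine. The pyridine rings also do not act alike against thiophen-3-yl: pyridin-4-yl gives an 11-fold lower number from compound 1 to compound 4 (1.03 log units; beyond the scatter), whereas pyridin-3-yl gave a 2.7-fold higher number from compound 1 to compound 2 (0.43 log units; beyond the scatter), in the opposite direction, so the earlier thiophene-to-pyridine step gave no sign of how much this position can move the number. No measurement here bears on what lies behind this shift.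

The compounds shown leave open whether pyridin-4-yl keeps its effect when combined with the methoxy change seen in compound 3, since the only methoxy comparison so far was made with pyridin-3-yl. They also leave open whether pyridin-2-yl, or a phenyl ring carrying an amine or a carboxylic acid, would give a number closer to compound 4 or to compound 2 at this position.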